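Pyrazole-to-tetrazole exchange on a MNK1 inhibitor scaffold

A few compounds are considered here, and "the series" means these few. Any claim that something is new, unique, unknown or untested is made for them only; others in the source may bear on it.

Of the compounds shown here, two have been measured in an assay on cells for inhibition of MAP kinase-interacting serine/threonine-protein kinase 1 (Homo sapiens), read by mobility shift assay, with stated times of 10 min and 60 min, in the presence of a further agent that is not named here; on this read-out lower numbers stand for stronger inhibition and higher numbers for weaker inhibition. Compound 1 `NC(=O)c1ccc(-c2cccnc2)cc1OC1CCNC1` gives 1900 nM in this assay. Compound 2 `Cc1c(-c2cncc(-c3ccc(C(N)=O)c(OC(C)C)c3)c2)cnn1C` gives 60 nM in this assay, the lower of the two numbers, and the gap to compound 1 lies beyond the scatter. Compound 3 `CC(C)Oc1cc(-c2cncc(-c3nn[nH]n3)c2)ccc1C(N)=O` has not yet been measured. It differs from compound 2 in one place: 2H-tetrazol-5-yl in place of 1,5-dimethyl-1H-pyrazol-4-yl on an aromatic carbon. Among the measured compounds shown here, no measured pair shows this particular exchange, so the size of its effect in this assay cannot be read from the data. On that basis the expectation rests only on the structure itself; compound 3 is expected to give a somewhat higher number than compound 2 in this assay, a step of a 5.0-fold higher number from compound 2 to compound 3 (0.70 log units; beyond the scatter) that would fall beyond the scatter, with a wide margin of uncertainty in both directions. Compound 3 is estimated at 300 nM, between 50 nM and 2000 nM, in this assay.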

Compound 3, half-maximal inhibitory concentration: 310 nM
Estimate against measurement, compound 3: 1.0-fold (0.01 log units) below; low and high end bracket the measured number.
By their numbers in this assay, from the lowest: compound 2; then compound 3; then compound 1.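

In this assay, replacing 1,5-dimethyl-1H-pyrazol-4-yl with 2H-tetrazol-5-yl gives a 5.2-fold higher number from compound 2 to compound 3 (0.71 log units; beyond the scatter), the only one-place comparison among the compounds shown. It shows that the number responds to the group on this aromatic carbon, two atoms from the ring nitrogen, while compound 3 still gives a measurable value of 310 nM. Nothing available explains the size or direction of this step.

As far as these compounds go, what remains open is whether the step follows from the change in the ring's hetero atoms, from the loss of the methyl groups, or from both together, as this single exchange alters all of these at once. A plain pyrazol-4-yl ring or a carboxylic acid on the same aromatic carbon would help to separate these possibilities.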